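From Bromo to Chloro: Expecting the Response of Compound 4

The source may hold more compounds than are shown below. What is called first, only, known or untested is meant among the compounds shown, and "the series" means these compounds.

Three compounds have so far been tested in a functional assay on aorta (Rattus norvegicus, strain Sprague-Dawley) for inhibition, with a stated time of 20 min; on this read-out higher numbers stand for larger maximal responses and lower numbers for smaller maximal responses:

Compound 1, `C=CCc1c(O)cc(O)c(C(=O)/C=C/c2ccc(O)cc2)c1O`, gives 108%.
Compound 2, `O=C1CC(c2cccc(Br)c2)Oc2cc(O)cc(O)c21`, gives 93.5%.
Compound 3, `C=CCc1c(O)cc(O)c2c1OC(c1cccc(Br)c1)CC2=O`, gives 78.8%.

Compound 3 stands lowest of these three numbers. Compound 2 is nearest to it and lies higher by more than the scatter; compound 1 is furthest away and higher still. Only one pair of these compounds differs in a single place: a number 14.7 percentage points lower from compound 2 to compound 3 (beyond the scatter), where an allyl replaces a hydrogen on an aromatic carbon.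

Compound 4, `C=CCc1c(O)cc(O)c2c1OC(c1cccc(Cl)c1)CC2=O`, differs from compound 3 by chloro in place of bromo on an aromatic carbon. Going by the values given here, no measured step exchanges one halogen for another, so the step from compound 2 to compound 3 does not bear directly on this change, and nothing among the measured compounds points to a shift in either direction. A step within the scatter is therefore expected: a number 1.2 percentage points higher from compound 3 to compound 4 (within the scatter). Compound 4 is accordingly estimated to give about 80%, with a range from 66% to 94%.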

Compound 4, largest response reached (Emax), in percent of the reference or control that the assay uses: 76.7%
Compound 4: the middle estimate sits 3.3 percentage points above what was measured; measured number inside the range.
By their numbers in this assay, from the lowest: compounds 4 and 3 (each within the scatter of the next); then compound 2; then compound 1.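

In this assay, the exchange of bromo for chloro reads as a number 2.1 percentage points lower from compound 3 to compound 4 (within the scatter). This is the first halogen exchange among these compounds, and it shows that on this read-out, bromo and chloro cannot be told apart at this place on the aromatic ring when the allyl group is present, something the earlier allyl step could not reveal. Nothing available explains why the two halogens read alike.

On these data alone, with only these two halogens compared, the effect of a very different group at this place, such as an amine, a methoxy group or a carboxylic acid, remains open. As far as these compounds go, it also remains open whether the 3-bromophenyl to 3-chlorophenyl exchange would read the same way on the shared core without the allyl group.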